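Two chlorines on the amide-side ring: expected maximal response

The source may hold more compounds than are shown below. What is called first, only, known or untested is meant among the compounds shown, and "the series" means these compounds.

Compound 1 `CSc1cccc(NC(=O)CN2CCC(c3cccc[n+]3[O-])CC2)c1` gives 56% in a functional assay on HEK293 cells for agonist activity at D(4) dopamine receptor (Homo sapiens), read by FLIPR; on this read-out higher numbers stand for larger maximal responses and lower numbers for smaller maximal responses.
Compound 2 `CC(C)Oc1cccc(NC(=O)CN2CCC(c3cccc[n+]3[O-])CC2)c1` gives 48% in this assay.
Compound 3 `O=C(CN1CCC(c2cccc[n+]2[O-])CC1)Nc1cccc(C(F)(F)F)c1` gives 75% in this assay.

Among these three numbers compound 1 stands second highest. The step of a number 8 percentage points lower from compound 1 to compound 2 (within the scatter) stays within the scatter, so the two cannot be ordered, whereas the step of a number 19 percentage points higher from compound 1 to compound 3 (beyond the scatter) goes beyond it, and the step of a number 27 percentage points higher from compound 2 to compound 3 (beyond the scatter) is larger still. All three compounds share the same core and differ only in the group on the aromatic ring attached to the amide nitrogen.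

Compound 4 `O=C(CN1CCC(c2cccc[n+]2[O-])CC1)Nc1cc(Cl)cc(Cl)c1` has not yet been measured in this assay. Its change from compound 1 is 3,5-dichlorophenyl in place of 3-(methylsulfanyl)phenyl on an amide-type nitrogen. Among the measured compounds shown here, no measured step exchanges the whole ring or introduces two chlorines; the steps that bear on it are the single-group swaps on that same ring, which moved the maximal response by a modest rise from compound 1 to compound 3 and by a change within the scatter from compound 1 to compound 2. A change of similar size, upward or none, is therefore expected. Compound 4 is estimated at 64%, with a range from 45% to 83%. This estimate means a step of a number 8 percentage points higher from compound 1 to compound 4 (within the scatter).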

Compound 4, largest response reached (reported as efficacy), in percent of the reference or control that the assay uses: 68%
Compound 4: middle estimate off by 4 percentage points, on the low side, within the range that was stated.
By their numbers in this assay, from the lowest: compounds 2 and 1 (each within the scatter of the next); then compounds 4 and 3 (each within the scatter of the next).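

Exchanging the whole 3-(methylsulfanyl)phenyl for 3,5-dichlorophenyl on the amide-type nitrogen is a step of a number 12 percentage points higher from compound 1 to compound 4 (beyond the scatter) in this assay, which shows that a ring carrying two chlorines can keep a sizeable maximal response here, whereas each earlier ring carried a single group. Compound 4 at 68% and compound 3 at 75% lie within the scatter of each other, so two chlorines and one trifluoromethyl group cannot be ordered on this read-out, and the hydrogen-bond acceptor counted on the leaving group is absent from the entering one without any loss of response. Nothing at hand bears on what lies behind this rise.

The compounds shown leave open whether a single chlorine would give a response like that of compound 4 or whether both chlorines are needed. Also open, going by these compounds, is how this assay would respond to a ring bearing an amine or a carboxylic acid, or to a longer chain in place of the ring on the amide-type nitrogen.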